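The compounds below may be only part of what the source reports. "The series", "measured", "known", "first", "only" and "open" are said of these compounds alone.

Compound 1 `Cc1ccc(CS/C(=C/c2ccc(F)c(C)c2)C(=O)c2ccc(Cl)cc2)cc1` was tested in a functional assay on DU-145 cells (Homo sapiens) for inhibition, read by trypan blue exclusion, with a stated time of 96 h (a lower number here means a stronger inhibitor of growth, a higher number a weaker inhibitor of growth), where compound 1 gives 25000 nM. For the measured compounds named here, the only other measured member of the set, compound 2 `COc1ccc(/C=C(/C(=O)c2ccc(OC)cc2)S(=O)(=O)Cc2ccc([N+](=O)[O-])cc2)cc1`, shares neither the chlorinated aryl ketone nor the thioether link of compound 1, and in this assay compound 2 gives 25000 nM. The two values agree at the digits shown, so compound 1 stands level with compound 2, with no change beyond the scatter between them.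

Compound 3 `Cc1ccc(CS/C(=C/c2sccc2C)C(=O)c2ccc(Cl)cc2)cc1` has not yet been measured. It differs from compound 1 in one place: 3-methylthiophen-2-yl in place of 4-fluoro-3-methylphenyl on a double-bonded chain carbon bound to a double-bonded chain carbon. Going by the values given here, no measured pair in this set reports such a change, so the size of its effect in this assay is unknown from these data. Among the compounds with values here, since the two compounds measured so far sit at the same value, compound 3 is expected to stay near them, with a step of about no change at the digits printed from compound 1 to compound 3 (within the scatter). Compound 3 is therefore estimated at 25000 nM, within a range from 10000 nM to 50000 nM.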

Compound 3, concentration for 50% growth inhibition: 10000 nM
Compound 3: the middle estimate sits 2.5-fold (0.40 log units) above what was measured, within the range that was stated.
By their numbers in this assay, from the lowest: compound 3; then compounds 1 and 2 (each within the scatter of the next).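

In this assay, the place on a double-bonded chain carbon bound to a double-bonded chain carbon responds to change: 3-methylthiophen-2-yl in place of 4-fluoro-3-methylphenyl gives a 2.5-fold lower number from compound 1 to compound 3 (0.40 log units; beyond the scatter) in this modest step, which lies beyond the scatter. The earlier compounds shown here could not show this, since compound 1 and compound 2 stand level and differ in more than one place, leaving this position without a reading of its own. Nothing measured here bears on the reason for the step.

The compounds shown leave open whether the five-membered ring with its sulfur or the loss of the fluorine carries the step, as both change together in compound 3. They also leave open how an amine or a carboxylic acid would read at this place.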